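The compounds below may be only part of what the source reports. "The series", "measured", "known", "first", "only" and "open" are said of these compounds alone.

Compound 3 `CNC(=O)c1cc(C(=O)N[C@H]2[C@@H]3C[C@@H](O)C[C@@H]32)cc2c1OC[C@@]2(C)c1ccccc1` sits second highest of the three numbers in a physicochemical assay for lipophilicity, at pH 7.4 (a higher number here means a more lipophilic compound, a lower number a more polar compound), with a value of 3.3. Its nearest neighbour is compound 1 `CNC(=O)c1cc(C(=O)N[C@H]2[C@@H]3COC[C@@H]32)cc2c1OC[C@@]2(CO)c1ccccc1`, which gives 2.4 in this assay, and the furthest is compound 2 `CNC(=O)c1cc(C(=O)N[C@H]2C[C@@H]2C)cc2c1OC[C@@]2(C)c1ccccc1`, which gives 4.7. Among the measured compounds shown here, the one measured step that bears on this series, a number 1.40 log units lower from compound 2 to compound 3 (beyond the scatter), shows how much a larger ring system carrying a hydroxyl lowers the number.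

Compound 4 `CNC(=O)c1cc(C(=O)N[C@H]2[C@@H]3COC[C@@H]32)cc2c1OC[C@@]2(C)c1ccccc1` differs from compound 3 in one place: a group of 6 heavy atoms (5 carbon, 1 oxygen; one three-membered non-aromatic ring of carbon only, one five-membered non-aromatic ring with 1 hetero atom) in place of a group of 7 heavy atoms (6 carbon, 1 oxygen; one three-membered non-aromatic ring of carbon only, one five-membered non-aromatic ring of carbon only), on an amide-type nitrogen. The hydroxyl that compound 3 carries is gone, while an oxygen now sits inside the five-membered ring. Compound 4 and compound 1 share the same ring system but differ on the core, where compound 1 carries a hydroxymethyl in place of a methyl, so the value of compound 1, 2.4, is not a direct match. In this assay compound 4 is expected to land moderately above compound 3, a step of a number 0.20 log units higher from compound 3 to compound 4 (within the scatter). The estimate for compound 4 is 3.5, with a range from 3 to 4.1.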

Compound 4, distribution coefficient: 3.7
The estimate for compound 4 lay 0.20 log units below the measured number; the measured number falls inside the stated range.
By their numbers in this assay, from the lowest: compound 1; then compound 3; then compound 4; then compound 2.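

In this assay, the group on the amide-type nitrogen matters even when both groups contain oxygen: a number 0.40 log units higher from compound 3 to compound 4 (beyond the scatter), as the group entering has 0 hydrogen-bond donors where the group leaving has 1. The group of compound 4 still gives a clear drop from the all-carbon group of 4 heavy atoms, with a number 1.00 log units lower from compound 2 to compound 4 (beyond the scatter), so much of the fall seen with the hydroxyl-bearing group remains without that hydroxyl. The core also counts, since hydrogen in place of hydroxy on the saturated chain carbon, with the amide group unchanged, gives a number 1.30 log units higher from compound 1 to compound 4 (beyond the scatter).

Going by these compounds, how an amine or a carboxylic acid on the group at this amide-type nitrogen would shift the number remains open. Nothing available explains why any of these steps has its size.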